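Methyl to Trifluoromethyl: Predicting Compound 3

This account rests on a few compounds, and the source may have more. Where it says the series, first, only, none or still open, it means among the compounds named here.

Compound 1 `CCc1ccc(/C=C/C(=O)c2ccc(-n3ccnc3)cc2)cc1` and compound 2 `Cc1ccc(/C=C/C(=O)c2ccc(-n3ccnc3)cc2)cc1` share one core and differ only in the chain bound to the aromatic carbon. In an assay on isolated protein for inhibition of Amine oxidase [flavin-containing] B (Homo sapiens) (on this read-out lower numbers stand for stronger inhibition and higher numbers for weaker inhibition), compound 1 gives 320 nM. In this assay compound 2 gives 320 nM. The step of no change at the digits printed from compound 1 to compound 2 (within the scatter) shows that replacing ethyl by methyl left the read-out where it was, and compound 2 therefore stands level with compound 1 on the numbers shown. Compound 3 `O=C(/C=C/c1ccc(C(F)(F)F)cc1)c1ccc(-n2ccnc2)cc1` carries the change (trifluoromethyl in place of methyl on an aromatic carbon). For the measured compounds named here, no measured step replaces a methyl by a trifluoromethyl, so the only guide is the one measured step at this position, from ethyl to methyl, which produced no change in this assay. The expected step is accordingly modest, a 1.1-fold higher number from compound 2 to compound 3 (0.04 log units; within the scatter), in no clear direction beyond the scatter. Compound 3 is expected to give 350 nM in this assay, within a range from 100 nM to 1200 nM.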

Compound 3, half-maximal inhibitory concentration: > 10000 nM
Compound 3: only a limit was reported; the forecaster's own chance of this, stated with the estimate: 5%; middle value at least 28-fold (1.45 log units) away from the limit.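

The position on an aromatic carbon para to a large group, where ethyl and methyl had read alike, turns out not to be indifferent to what sits there. In this assay, trifluoromethyl in place of methyl gives an at least 31-fold higher number from compound 2 to compound 3 (1.49 log units; beyond the scatter), and trifluoromethyl in place of ethyl gives an at least 31-fold higher number from compound 1 to compound 3 (1.49 log units; beyond the scatter), so the level shared by the two earlier compounds holds only for those two chains. The value of compound 3 is a limit and not a number: the limit of > 10000 nM in this assay, at which 1 of the 3 values shown sits.

The compounds shown do not tell how far past that limit compound 3 lies. They also leave open how a single fluorine, a chlorine, a methoxy group or a longer chain such as propyl would read at this position, and so whether the drop belongs to trifluoromethyl alone.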